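From 2-Methylbenzyl to 4-Chlorobenzyl on a Shared Core

This account rests on a few compounds, and the source may have more. Where it says the series, first, only, none or still open, it means among the compounds named here.

In a functional assay on U-251 cells (Homo sapiens) for antiproliferative activity, read by MTT assay, with a stated time of 24 h (on this read-out lower numbers stand for stronger inhibition and higher numbers for weaker inhibition), compound 1 (`COc1cc(OC)c(-c2coc3cc(OCc4ccccc4)ccc3c2=O)cc1OC`) gives 6750 nM while compound 2 (`COc1cc(OC)c(-c2coc3cc(OCc4ccc(F)cc4)ccc3c2=O)cc1OC`) gives 3200 nM and compound 3 (`COc1cc(OC)c(-c2coc3cc(OCc4ccccc4C)ccc3c2=O)cc1OC`) gives 2000 nM in the same test. Compound 3 is separated on one side only: the data show a 3.4-fold lower number from compound 1 to compound 3 (0.53 log units; beyond the scatter) but also a 1.6-fold lower number from compound 2 to compound 3 (0.20 log units; within the scatter) and so no separation from its nearest neighbour. Compound 4 (`COc1cc(OC)c(-c2coc3cc(OCc4ccc(Cl)cc4)ccc3c2=O)cc1OC`) carries 4-chlorophenyl in place of 2-methylphenyl on a saturated chain carbon bound to an oxygen on an aromatic ring. Within the data shown here, no chlorine-bearing analogue has been measured. The closest guide is the 4-fluorophenyl group, with a 2.1-fold lower number from compound 1 to compound 2 (0.32 log units; beyond the scatter) as a modest step. No step beyond the scatter is therefore expected, and the estimated change is a 1.5-fold higher number from compound 3 to compound 4 (0.18 log units; within the scatter) in this assay overall. Compound 4 is estimated at 3000 nM with an expected range from 1200 nM to 7000 nM in this test.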

Compound 4, half-maximal inhibitory concentration: 470 nM
Compound 4: middle estimate off by 6.4-fold (0.81 log units), on the high side; measured number below the stated range.
By their numbers in this assay, from the lowest: compound 4; then compounds 3 and 2 (each within the scatter of the next); then compound 1.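

In this assay, among these compounds, this saturated chain carbon bound to an oxygen on an aromatic ring proves more responsive than the earlier compounds showed, with 4-chlorophenyl bringing a 14-fold lower number from compound 1 to compound 4 (1.16 log units; beyond the scatter) and also a 4.3-fold lower number from compound 3 to compound 4 (0.63 log units; beyond the scatter), clear of its nearest neighbour. The two halogens do not read alike here, as chloro in place of fluoro on an aromatic carbon gives a 6.8-fold lower number from compound 2 to compound 4 (0.83 log units; beyond the scatter) on the same phenyl ring. No measurement at hand explains this gap. The compounds shown leave open whether a bromo, trifluoromethyl or amine group on that ring would follow chloro. They also leave open whether the gain survives with chloro elsewhere on the ring.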